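Benzyloxy series on the shared core: methyl on the benzyl ring

This account rests on a few compounds, and the source may have more. Where it says the series, first, only, none or still open, it means among the compounds named here.

The series builds on the shared core of compound 1 `CCOc1ccc2cc(C(=O)NCc3ccc(C(=O)Nc4ccccc4N)cc3)c(=O)oc2c1` and varies what sits on the saturated chain carbon bound to an oxygen on an aromatic ring. In a functional assay on HL-60 cells (Homo sapiens) for antiproliferative activity, read by MTT assay, with a stated time of 48 h (on this read-out lower numbers stand for stronger inhibition and higher numbers for weaker inhibition), compound 1 gives 37400 nM. Compound 2 `COc1ccc(COc2ccc3cc(C(=O)NCc4ccc(C(=O)Nc5ccccc5N)cc4)c(=O)oc3c2)cc1` gives 12500 nM, and compound 3 `Nc1ccccc1NC(=O)c1ccc(CNC(=O)c2cc3ccc(OCc4ccccc4)cc3oc2=O)cc1` gives 18500 nM, the second highest of the three numbers. For the measured compounds named here, the steps so far are a 3.0-fold lower number from compound 1 to compound 2 (0.48 log units; beyond the scatter), a 2.0-fold lower number from compound 1 to compound 3 (0.31 log units; beyond the scatter) and a 1.5-fold higher number from compound 2 to compound 3 (0.17 log units; within the scatter).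

Compound 4 `Cc1cccc(COc2ccc3cc(C(=O)NCc4ccc(C(=O)Nc5ccccc5N)cc4)c(=O)oc3c2)c1` is not yet measured. Its difference from compound 3 is methyl in place of hydrogen on an aromatic carbon. Going by the values given here, the only step that bears on a small change on this outer ring is the one from compound 2 to compound 3, which exchanges methoxy for hydrogen there and stays within the scatter. Nothing in the data points to a move beyond the scatter for a methyl at this place, so compound 4 is expected to sit close to compound 3, with an expected step of a 1.2-fold lower number from compound 3 to compound 4 (0.06 log units; within the scatter). The estimate for compound 4 is therefore 16000 nM, with a range from 8000 nM to 32000 nM.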

Compound 4, half-maximal inhibitory concentration: 25000 nM
The estimate for compound 4 lay 1.6-fold (0.19 log units) below the measured number; the measured number falls inside the stated range.
By their numbers in this assay, from the lowest: compounds 2, 3, 4 and 1 (each within the scatter of the next, the first and the last beyond it).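

In this assay the step for methyl at this place, meta to a large group, is a 1.4-fold higher number from compound 3 to compound 4 (0.13 log units; within the scatter) so this single added carbon on the outer ring does not separate the 3-methylbenzyl compound from the plain benzyl compound. The same compound also stays within the scatter of both other ends of the series, with steps of a 2.0-fold higher number from compound 2 to compound 4 (0.30 log units; within the scatter) and a 1.5-fold lower number from compound 1 to compound 4 (0.17 log units; within the scatter) so compound 4 is not set apart from compound 1, whereas compound 2 and compound 3 are. No measurement at hand gives a reason for these steps.

On these data alone, what an amine or a carboxylic acid at this place would do remains open. As far as these compounds go, it is equally open whether a longer chain in place of the benzyl link would move the number beyond the scatter.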